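Swapping the amine substituent in a coumarin-amide series

The compounds below may be only part of what the source reports. "The series", "measured", "known", "first", "only" and "open" are said of these compounds alone.

Compound 2 `CC(C)=CCc1cc(C(=O)Nc2cc3ccc(OCCCNC4CCCCC4)c(C)c3oc2=O)ccc1O` was measured in a functional assay on SK-BR-3 cells (Homo sapiens) for antiproliferative activity (a lower number here means a stronger inhibitor, a higher number a weaker inhibitor), where compound 2 gives 660 nM. Its closest relative is compound 1 `CCCNCCCOc1ccc2cc(NC(=O)c3ccc(O)c(CC=C(C)C)c3)c(=O)oc2c1C`; in this assay compound 1 gives 990 nM. Compound 2 carries the lower of the two numbers, but the step of a 1.5-fold lower number from compound 1 to compound 2 (0.18 log units; within the scatter) lies within the scatter, so the two compounds cannot be told apart on these data.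

Compound 3 `CC(C)=CCc1cc(C(=O)Nc2cc3ccc(OCCCN(C)Cc4ccccc4)c(C)c3oc2=O)ccc1O` has not yet been measured. Its difference from compound 2 is benzyl(methyl)amino in place of cyclohexylamino on a saturated chain carbon, three bonds along the chain from an oxygen on an aromatic ring. Among the measured compounds shown here, the only step that bears on this position is the one from compound 1 to compound 2, which changed the group on the amine nitrogen and stayed within the scatter. On that basis the expected step of a 1.1-fold higher number from compound 2 to compound 3 (0.03 log units; within the scatter) is small, with no direction beyond the scatter. For compound 3 the estimate in this assay is 700 nM, with a range from 300 nM to 1600 nM.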

Compound 3, half-maximal inhibitory concentration: 10700 nM
The estimate for compound 3 lay 15-fold (1.18 log units) below the measured number; the whole stated range lies below it.
By their numbers in this assay, from the lowest: compounds 2 and 1 (each within the scatter of the next); then compound 3.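

In this assay the group on this amine nitrogen is not freely exchangeable: benzyl(methyl)amino in place of cyclohexylamino gives a 16-fold higher number from compound 2 to compound 3 (1.21 log units; beyond the scatter) and, in place of propylamino, gives an 11-fold higher number from compound 1 to compound 3 (1.03 log units; beyond the scatter) while the earlier swap of propyl for cyclohexyl stayed within the scatter. The change alters two things at once, since the entering group has an aromatic ring and no hydrogen-bond donor, whereas the groups it replaces have a donor and no aromatic ring, so these compounds cannot assign the step to either feature. No measurement at hand explains the step. 

As far as these compounds go, whether the step follows the methyl or the benzyl group stays open, and a benzylamino or a cyclohexyl(methyl)amino group on this chain would separate the two. From the compounds shown here alone, how a piperidine at this position would read in this assay is also open.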